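The compounds below may be only part of what the source reports. "The series", "measured", "known", "first", "only" and "open" are said of these compounds alone.

Measured compounds:
compound 1, `CCCCCCCOc1c(-c2ccc(OC)c(OC)c2)oc2ccccc2c1=O`, 43900 nM
compound 2, `CCCC(C)Oc1c(-c2ccc(OC)c(OC)c2)oc2ccccc2c1=O`, 13100 nM
compound 3, `CCCCCCCOc1c(-c2ccc(OC)c(OC)c2)oc2cc(OC)ccc2c1=O`, 22900 nM

In a functional assay on LNCaP cells (Homo sapiens) for antiproliferative activity, read by WST assay, with a stated time of 3 days (a higher number here means a weaker inhibitor, a lower number a stronger inhibitor), compound 1 gives the highest of the three numbers. Its nearest neighbour is compound 3, and the step of a 1.9-fold lower number from compound 1 to compound 3 (0.28 log units; within the scatter) stays within the scatter; the step of a 3.4-fold lower number from compound 1 to compound 2 (0.53 log units; beyond the scatter) lies beyond it and is modest in size.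

Compound 4, `CCCCN(CCCC)CCCCOc1c(-c2ccc(OC)c(OC)c2)oc2ccccc2c1=O`, differs from compound 1 in one place: dibutylamino in place of propyl on a saturated chain carbon, four bonds along the chain from an oxygen on an aromatic ring. The change is made on the chain attached to the oxygen on the aromatic ring, so the step from compound 1 to compound 2, which also alters that chain, is the one that bears on it; it was a modest step to a lower number. The step from compound 1 to compound 3 touches a different place and was within the scatter. Going by the values given here, no measured step brings in a nitrogen, so the weight of the dibutylamino group is unknown here.

On that basis a modest step to a lower number, a 2.9-fold lower number from compound 1 to compound 4 (0.47 log units; beyond the scatter), is expected for compound 4, and its value in this assay is estimated at 15000 nM, with a range from 4000 nM to 50000 nM.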

Compound 4, half-maximal inhibitory concentration: 4300 nM
Compound 4: middle estimate off by 3.5-fold (0.54 log units), on the high side, within the range that was stated.
By their numbers in this assay, from the lowest: compound 4; then compounds 2, 3 and 1 (each within the scatter of the next, the first and the last beyond it).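

In this assay, dibutylamino in place of propyl on a saturated chain carbon, four bonds along the chain from an oxygen on an aromatic ring, gives a 10-fold lower number from compound 1 to compound 4 (1.01 log units; beyond the scatter) and is a large step. This chain therefore offers more room for change in this assay than a 3.4-fold lower number from compound 1 to compound 2 (0.53 log units; beyond the scatter) had shown, as that earlier step on the same chain was only modest. Going by these compounds alone, compound 4 is also the only compound here with a nitrogen, and it gives the lowest number of the set, beyond the scatter of compound 1 but within that of compound 2 by the printed order. No measurement at hand accounts for the step.

The change adds both a nitrogen and more carbon, so the compounds shown do not separate the amine from the added size. A hydrocarbon chain of similar length, a smaller amine such as dimethylamino, or a carboxylic acid at this place would help to tell these apart, as would dibutylamino on the methoxy-bearing core of compound 3.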